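Chloro for bromo: expected effect on cytotoxicity

The compounds below may be only part of what the source reports. "The series", "measured", "known", "first", "only" and "open" are said of these compounds alone.

Measured compounds:
compound 1, `O=C(CCCCC1CCSS1)NCc1cn(CCCOc2ccc3cc(-c4ccc(Br)cc4)c(=O)oc3c2)nn1`: 39.5%
compound 2, `O=C(CCCCC1CCSS1)NCc1cn(CCCOc2ccc3cc(-c4ccc(Cl)cc4)c(=O)oc3c2)nn1`: 40.9%
compound 3, `O=C(CCCCC1CCSS1)NCc1cn(CCCCOc2ccc3cc(-c4ccc(Br)cc4)c(=O)oc3c2)nn1`: 34.2%

In a functional assay on PC-12 cells (Rattus norvegicus) for cytotoxicity, read by MTT assay, with stated times of 3 h and 2 h, tested at 0.1 uM (on this read-out lower numbers stand for a weaker effect and higher numbers for a stronger effect at the one concentration tested), compound 1 gives 39.5% and compound 2 gives 40.9%. The change chloro in place of bromo on an aromatic carbon produced a number 1.4 percentage points higher from compound 1 to compound 2 (within the scatter). Compound 3 gives 34.2% in this assay; its difference from compound 1 is not broken down here, and its numbers against compound 1 and compound 2 are within the scatter.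

Compound 4, `O=C(CCCCC1CCSS1)NCc1cn(CCCCOc2ccc3cc(-c4ccc(Cl)cc4)c(=O)oc3c2)nn1`, has not been measured. It differs from compound 3 by chloro in place of bromo on an aromatic carbon, the same change as between compound 1 and compound 2. Because a number 1.4 percentage points higher from compound 1 to compound 2 (within the scatter) was small, the step from compound 3 is expected to be a number 1.8 percentage points higher from compound 3 to compound 4 (within the scatter) in this assay. Compound 4 is therefore estimated at 36%, expected between 28% and 44%.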

Compound 4, a percentage reported as activity, at one concentration (the size of the read-out at that concentration, not a potency): 38.8%
Beside the measured number, compound 4's estimate is 2.8 percentage points below it; the measured number falls inside the stated range.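

Carried to a second core, the change from 4-bromophenyl to 4-chlorophenyl gave a number 4.6 percentage points higher from compound 3 to compound 4 (within the scatter) in this assay. Set beside the earlier case, the two steps do not differ: the same change on two cores in this assay, a number 1.4 percentage points higher (within the scatter) from compound 1 to compound 2 and a number 4.6 percentage points higher (within the scatter) from compound 3 to compound 4, 3.2 percentage points apart, within the scatter of two such steps. On these two cores, the change therefore left the read-out within the scatter each time, but this does not show that it has a real effect of its own or that it would behave alike on any other core.

The compounds shown leave open what a fluoro, methoxy or amino group would do in place of the halogen on the aromatic ring. They also leave open how either halogen would read with a longer chain.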